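Triazole aryl swap on a pyranopyridinone series

The source may report more compounds than this note shows. Statements on the series, on what has been measured and on what is new or still open speak of the compounds shown alone.

Compound 1 `CCCCCc1ccc(C#Cc2c(-c3ccc(CCCCC)cc3)oc3nc(=O)n(Cc4cn(-c5ccccc5F)nn4)cc23)cc1` gives 38700 nM in a functional assay on A549 cells (Homo sapiens) for antiproliferative activity, read by MTT assay, with a stated time of 72 h; a lower number here means a stronger inhibitor, a higher number a weaker inhibitor. Compound 2 `CCCCCc1ccc(C#Cc2c(-c3ccc(CCCCC)cc3)oc3nc(=O)n(Cc4cn(-c5ccc(Cl)cc5)nn4)cc23)cc1` reaches only the limit of > 100000 nM in this assay, so for compound 2 there is a bound rather than a number. Among the measured compounds shown here, the one measured step, an at least 2.5-fold higher number from compound 1 to compound 2 (0.41 log units; beyond the scatter), ends on the limit of > 100000 nM in this assay, at which 1 of the 2 values shown sits, and its full size is not known. Compound 3 `CCCCCc1ccc(C#Cc2c(-c3ccc(CCCCC)cc3)oc3nc(=O)n(Cc4cn(Cc5ccccc5)nn4)cc23)cc1` differs from compound 2 by benzyl in place of 4-chlorophenyl on an aromatic nitrogen. For the measured compounds named here, no measured step changes a phenyl into a benzyl at this position, so the step from compound 2 to compound 3 is not covered by the series; the only guidance is that both measured compounds sit at the weak end of this assay and compound 2 is at its limit. A number near that limit is therefore expected for compound 3, an at least 1.4-fold lower number from compound 2 to compound 3 (0.15 log units; that floor lies within the scatter) being the step implied, with the direction uncertain. Compound 3 is estimated at 70000 nM, within 25000 nM to 200000 nM.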

Compound 3, half-maximal inhibitory concentration: > 100000 nM
Compound 3 ended at the assay's limit; the forecaster's own chance of this, stated with the estimate: 45%; middle value at least 1.4-fold (0.15 log units) from the limit.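

With benzyl in place of 2-fluorophenyl on the aromatic nitrogen, this assay shows an at least 2.5-fold higher number from compound 1 to compound 3 (0.41 log units; beyond the scatter), so a second group, one not attached to this nitrogen through an aromatic ring carbon, also ends weaker than compound 1. The values of compound 2 and compound 3 are both limits, so the step between them cannot be read and the 4-chlorophenyl and benzyl groups cannot be ranked. Among these groups on this nitrogen, only the 2-fluorophenyl of compound 1 gives a readable number, and the other two compounds end at the limit: the limit of > 100000 nM in this assay, at which 2 of the 3 values shown sit.

Open, as far as these compounds go, is whether unsubstituted phenyl, 2-chlorophenyl or an alkyl chain carrying an amine on this nitrogen would give a readable number. From the compounds shown here alone, the pentyl chains stay constant across the series, so the effect of a shorter chain or a carboxylic acid in their place is also open.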